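The source may report more compounds than this note shows. Statements on the series, on what has been measured and on what is new or still open speak of the compounds shown alone.

Compound 1 `CC/C(=C(/c1ccc(/C=C/C(=O)O)cc1)c1ccc(O)nc1)c1ccccc1`: in a functional assay on MCF7 cells (Homo sapiens) for cytotoxicity, read by CellTiter-Glo, with a stated time of 5 days (a higher number here means a weaker inhibitor, a lower number a stronger inhibitor), compound 1 gives "not determined" (no result reported).
Compound 2 `CC/C(=C(/c1ccc(/C=C/C(=O)O)cc1)c1ccc2[nH]c(=O)oc2c1)c1ccccc1`: in this assay compound 2 gives 56 nM.
Compound 3 `CC/C(=C(/c1ccc(/C=C/C(=O)O)cc1)c1ccc2[nH]ncc2c1)c1ccc(Cl)cc1`: in this assay compound 3 gives 15 nM.

Two of the three compounds sharing this core have a number, and compound 3 holds the lower of the two; compound 2 sits higher, a gap beyond the usual scatter of repeated measurements. Compound 1 has no reported result, so nothing can be said of it.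

Compound 4 `CC/C(=C(/c1ccc(/C=C/C(=O)O)cc1)c1ccc2[nH]ncc2c1)c1cnccc1C` differs from compound 3 in one place: 4-methylpyridin-3-yl in place of 4-chlorophenyl on a double-bonded chain carbon bound to a double-bonded chain carbon and a saturated chain carbon. Both groups have the same count of heavy atoms; the entering group carries one hydrogen-bond acceptor where the leaving group had none.

Going by the values given here, no measured pair shows what this exchange does, so the expectation rests on compound 3 alone. A modest weakening seems most likely, possibly no larger than the scatter, and a strengthening cannot be ruled out. Compound 4 is expected to give about 35 nM, with a likely range from 10 nM to 120 nM. The step this estimate implies is a 2.3-fold higher number from compound 3 to compound 4 (0.37 log units; beyond the scatter).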

Compound 4, half-maximal inhibitory concentration: 150 nM
Compound 4: middle estimate off by 4.3-fold (0.63 log units), on the low side, and the stated range ends below it.
By their numbers in this assay, from the lowest: compound 3; then compound 2; then compound 4.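

In this assay, the exchange of 4-chlorophenyl for 4-methylpyridin-3-yl on the double-bonded chain carbon gives a 10-fold higher number from compound 3 to compound 4 (1.00 log units; beyond the scatter). This shows that the position is sensitive to which ring it carries, even though both groups have the same count of heavy atoms and neither has a net charge. No measurement shown here accounts for this step, so its cause stays unknown.

The exchange removes the chlorine, adds a methyl and puts a nitrogen into the ring all at once, so the compounds shown cannot say which of these changes matters most. From the compounds shown here alone, a 4-methylphenyl group in the same place would keep the methyl without the ring nitrogen, while a pyridin-3-yl group would keep the ring nitrogen without the methyl, and how either would read remains open.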